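Swapping a Pyridine for an Alkyne on the Side Chain

A few compounds are considered here, and "the series" means these few. Any claim that something is new, unique, unknown or untested is made for them only; others in the source may bear on it.

Compound 1 `O=C(O)CCCO/N=c1/ccn([C@@H]2O[C@H](COP(=O)(O)OP(=O)(O)OP(=O)(O)O)[C@@H](O)[C@H]2O)c(=O)[nH]1` gives 470 nM in a functional assay on 1321-N1 cells for agonist activity at P2Y purinoceptor 4 (Homo sapiens), read by scintillation counting and inositol phosphate accumulation; on this read-out lower numbers stand for an effect already at smaller amounts and higher numbers for an effect only at larger amounts of compound.
Compound 2 `COc1ccc(CCCO/N=c2/ccn([C@@H]3O[C@H](COP(=O)(O)OP(=O)(O)OP(=O)(O)O)[C@@H](O)[C@H]3O)c(=O)[nH]2)cc1` gives 23 nM in this assay.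
Compound 3 `O=c1[nH]/c(=N\OCCCc2ccncc2)ccn1[C@@H]1O[C@H](COP(=O)(O)OP(=O)(O)OP(=O)(O)O)[C@@H](O)[C@H]1O` gives 250 nM in this assay.

Among the three measured compounds, compound 3 has the second highest number in this assay; its nearest neighbour is compound 1, with a 1.9-fold lower number from compound 1 to compound 3 (0.27 log units; within the scatter) separating them, while compound 2 lies furthest away, with an 11-fold higher number from compound 2 to compound 3 (1.04 log units; beyond the scatter).

Compound 4 `C#CCCCO/N=c1/ccn([C@@H]2O[C@H](COP(=O)(O)OP(=O)(O)OP(=O)(O)O)[C@@H](O)[C@H]2O)c(=O)[nH]1` differs from compound 3 by ethynyl in place of pyridin-4-yl on a saturated chain carbon, three bonds along the chain from an oxygen. Among the measured compounds shown here, no measured step changes this position to a group without a ring, so none bears on it directly. What the measured steps do show is that the group at this position can matter greatly: a 20-fold lower number from compound 1 to compound 2 (1.31 log units; beyond the scatter) was large, whereas a 1.9-fold lower number from compound 1 to compound 3 (0.27 log units; within the scatter) stayed within the scatter. Compound 3 and compound 1 therefore give similar numbers despite quite different groups at this position, and only compound 2 stands apart.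

For the measured compounds named here, with no direct precedent, compound 4 is expected to land near compound 3 or somewhat above it, an expected 1.8-fold higher number from compound 3 to compound 4 (0.26 log units; within the scatter). The estimate for compound 4 in this assay is 450 nM, with an expected range from 120 nM to 1700 nM.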

Compound 4, half-maximal effective concentration: 410 nM
The estimate for compound 4 lay 1.1-fold (0.04 log units) above the measured number, and the stated range covers the measured number.
By their numbers in this assay, from the lowest: compound 2; then compounds 3, 4 and 1 (each within the scatter of the next).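

The step of a 1.6-fold higher number from compound 3 to compound 4 (0.21 log units; within the scatter) shows that a ring is not needed at this position to stay level with compound 3: ethynyl, with 2 heavy atoms and no ring, gives a number within the scatter of that of pyridin-4-yl, with 6 heavy atoms and a ring. Ethynyl also sits with carboxy, with a 1.1-fold lower number from compound 1 to compound 4 (0.06 log units; within the scatter) inside the scatter, so three quite different end groups on the same chain now fall together, while 4-methoxyphenyl stands alone, with an 18-fold higher number from compound 2 to compound 4 (1.25 log units; beyond the scatter) as a large step. Having a ring at the end of the chain therefore does not by itself sort these compounds, since compound 3 carries one and still groups with compound 1 and compound 4; the low number goes only with the 4-methoxyphenyl of compound 2.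

No measurement shown here explains why these end groups group as they do. Going by these compounds, whether the low number of compound 2 would hold with a plain phenyl or a 4-chlorophenyl on this chain, and how an amine at this position would compare, stays open.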